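The source may report more compounds than this note shows. Statements on the series, on what has been measured and on what is new or still open speak of the compounds shown alone.

Compound 1, `CC(O)(CSc1ccccc1)c1nc(-c2ccccc2)no1`, gives in a functional assay on DU-145 cells (Homo sapiens) for cytotoxicity, read by MTT assay (on this read-out higher numbers stand for weaker inhibition and lower numbers for stronger inhibition), only a limit of the assay, > 100000 nM.
Compound 2, `CC(O)(CSc1ccccc1)c1nc(-c2ccc(F)c(Cl)c2)no1`, gives in this assay 5500 nM.
Compound 3, `CC(O)(CS(=O)(=O)c1ccccc1)c1nc(-c2ccccc2)no1`, gives in this assay only a limit of the assay, > 100000 nM.

Among the measured compounds shown here, compound 2 therefore holds the only number among the three values; the other two sit at the limit of > 100000 nM in this assay, at which 2 of the 3 values shown sit. For the measured compounds named here, the single measured step, an at least 18-fold lower number from compound 1 to compound 2 (1.25 log units; beyond the scatter), concerns the phenyl ring attached directly to the shared core, and it is large.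

Compound 4, `CC(O)(CSc1ccc(F)cc1)c1nc(-c2ccc(F)c(Cl)c2)no1`, differs from compound 2 on the other ring: fluoro in place of hydrogen on an aromatic carbon, which reads phenylsulfanyl to (4-fluorophenyl)sulfanyl when cut one bond further out. Going by the values given here, no measured step touches this ring. Compound 3 differs from compound 1 only in the sulfur group, yet compound 3 returns a limit, not a number, so that pair gives no measure of how the sulfur side matters. Among the compounds with values here, the one large step, from compound 1 to compound 2, lies on a different ring and does not bear on this change.

Within the data shown here, with no step bearing on it, compound 4 is expected to show no step beyond the scatter, a 1.1-fold lower number from compound 2 to compound 4 (0.04 log units; within the scatter). The estimate for compound 4 in this assay is 5000 nM, with a range from 2200 nM to 12000 nM.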

Compound 4, half-maximal inhibitory concentration: 2900 nM
The estimate for compound 4 lay 1.7-fold (0.24 log units) above the measured number, and the stated range covers the measured number.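

Among the compounds shown here, the step of a 1.9-fold lower number from compound 2 to compound 4 (0.28 log units; within the scatter) is the first readable measure of a change on the sulfur-linked ring, which no earlier step had touched. In this assay, fluoro on an aromatic carbon, para to a large group, turning phenylsulfanyl into (4-fluorophenyl)sulfanyl, stays within the scatter with 3-chloro-4-fluorophenyl on the other side of the shared core, unlike the large step on that other ring, an at least 18-fold lower number from compound 1 to compound 2 (1.25 log units; beyond the scatter). Nothing shown bears on why this change leaves the number within the scatter.

Steps that run to or from a compound at a limit of the assay, such as any comparison of the sulfonyl compound 3 with compound 1, cannot be read: the limit of > 100000 nM in this assay, at which 2 of the 4 values shown sit. Also open, as far as these compounds go, is whether an amine or a carboxylic acid in place of the fluoro would move the number beyond the scatter, and whether the fluoro would behave the same way with plain phenyl on the other side of the core.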